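The source may report more compounds than this note shows. Statements on the series, on what has been measured and on what is new or still open speak of the compounds shown alone.

Within the data shown here, in a functional assay on A549 cells (Homo sapiens) for antiproliferative activity, with a stated time of 72 h (a higher number here means a weaker inhibitor, a lower number a stronger inhibitor), compound 1 (`C/C(=C\c1csc(C)n1)[C@@H]1C[C@@H]2OC(c3ccccc3)=N[C@H]2CCC[C@H](C)[C@H](O)[C@@H](C)C(=O)C(C)(C)[C@@H](O)CC(=O)O1`) gives 16.4 nM, the lower of the two numbers measured so far, and compound 2 (`CCc1ccc(C2=N[C@H]3CCC[C@H](C)[C@H](O)[C@@H](C)C(=O)C(C)(C)[C@@H](O)CC(=O)O[C@H](/C(C)=C/c4csc(C)n4)C[C@@H]3O2)cc1`) gives 379 nM. Compound 3 (`C/C(=C\c1csc(C)n1)[C@@H]1C[C@@H]2OC(c3ccc(C(C)(C)C)cc3)=N[C@H]2CCC[C@H](C)[C@H](O)[C@@H](C)C(=O)C(C)(C)[C@@H](O)CC(=O)O1`) differs from compound 1 by tert-butyl in place of hydrogen on an aromatic carbon, para to a large group: tert-butyl in place of hydrogen on an aromatic carbon. Among the measured compounds shown here, one measured step bears on this change: ethyl in place of hydrogen on an aromatic carbon gives a 23-fold higher number from compound 1 to compound 2 (1.36 log units; beyond the scatter). A large step of similar size towards a higher number is therefore expected in this assay, and the estimated step is a 27-fold higher number from compound 1 to compound 3 (1.44 log units; beyond the scatter). Compound 3 is expected at 450 nM, with an estimated range of 90 nM to 2000 nM.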

Compound 3, half-maximal inhibitory concentration: > 10000 nM
Compound 3: a limit, no number; the forecaster's own chance of this, stated with the estimate: 5%; at least 22-fold (1.34 log units) between middle value and limit.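

On the aromatic carbon para to a large group, tert-butyl goes beyond what ethyl showed: the change gives an at least 600-fold higher number from compound 1 to compound 3 (2.78 log units; beyond the scatter), and tert-butyl in place of ethyl still gives an at least 26-fold higher number from compound 2 to compound 3 (1.42 log units; beyond the scatter). Across compound 1, compound 2 and compound 3, the number therefore rises from hydrogen to ethyl to tert-butyl, with no compound shown against this order. For compound 3 the reading is a limit and not a number: the limit of > 10000 nM in this assay, at which 1 of the 3 values shown sits.

The compounds shown leave open whether a fluorine atom, a methoxy group or an amine on this carbon would keep the number close to that of compound 1. They also leave open how far the rise extends to other alkyl groups, such as methyl.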